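Chromanol series: replacing the dimethylaminoethyl chain in this assay

A few compounds are considered here, and "the series" means these few. Any claim that something is new, unique, unknown or untested is made for them only; others in the source may bear on it.

Two compounds of the series have numbers. Compound 1 `Cc1c(C)c2c(c(C)c1O)CC[C@@](C)(CC(=O)[N-][N+](C)(C)C)O2` gives 9000 nM in a functional assay (brain) for inhibition, with Rattus norvegicus as the target; a higher number here means a weaker inhibitor, a lower number a stronger inhibitor. Compound 2 `Cc1c(C)c2c(c(C)c1O)CC[C@](C)(CCN(C)C)O2` gives 1000 nM in this assay, the lowest of the two numbers shown; its nearest neighbour is compound 1, a gap beyond the scatter of repeated measurements.

Compound 3 `Cc1c(C)c2c(c(C)c1O)CC[C@](C)(CC(=O)[N-][N+](C)(C)C)O2` has not been measured. It differs from compound 2 in one place: a group of 7 heavy atoms (4 carbon, 2 nitrogen, 1 oxygen; no ring) in place of a group of 4 heavy atoms (3 carbon, 1 nitrogen; no ring), on a saturated chain carbon bound to a saturated ring carbon. For the measured compounds named here, no measured pair that differs only in this way exists, so the size of the step cannot be read from the data.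

The group that enters in compound 3 is also the group carried by compound 1, on the same core. The step is therefore expected to go upward, toward a weaker inhibitor, by a size clearly beyond the scatter, because compound 1 gives 9000 nM in this assay. The estimated step is a 6.0-fold higher number from compound 2 to compound 3 (0.78 log units; beyond the scatter). Compound 3 is expected to give 6000 nM in this assay, within a range from 2000 nM to 20000 nM.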

Compound 3, half-maximal inhibitory concentration: 8000 nM
For compound 3 the middle estimate is 1.3-fold (0.12 log units) below the measured one; the range from low to high includes it.
By their numbers in this assay, from the lowest: compound 2; then compounds 3 and 1 (each within the scatter of the next).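

In this assay, the replacement of (dimethylamino)methyl on a saturated chain carbon bound to a saturated ring carbon now has a measured size on a pair that differs in that one place (an 8.0-fold higher number from compound 2 to compound 3 (0.90 log units; beyond the scatter)), and the step is beyond the scatter, though it is rated modest. The drawn configuration of the stereocentre at a saturated ring carbon, by contrast, has no effect that can be read in this assay when this larger group is present (a 1.1-fold lower number from compound 1 to compound 3 (0.05 log units; within the scatter)), as that step lies within the scatter. This pair therefore tests the stereocentre on its own, with the group held constant: the fact that compounds 1 and 3 differ only in the configuration as drawn.

The compounds shown include no partner of compound 2 with the opposite drawn configuration, so it remains open whether the stereocentre is equally silent when the chain carries the (dimethylamino)methyl group. From the compounds shown here alone, it also remains open whether a primary amine, a carboxylic acid or a longer chain in this place would stay near compound 2 at 1000 nM or move further up in this assay.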